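From 3-chlorophenyl to 2-phenylethenyl on the shared core

The compounds below may be only part of what the source reports. "The series", "measured", "known", "first", "only" and "open" are said of these compounds alone.

Among the compounds with values here, compound 2 `O=C1C(=Cc2cccc(Cl)c2)C(=O)N(c2ccc(Cl)cc2)N1c1ccc(Cl)cc1` gives 14400 nM in a functional assay on MGC-803 cells (Homo sapiens) for cytotoxicity, read by MTT assay, with a stated time of 72 h (a higher number here means a weaker inhibitor, a lower number a stronger inhibitor), the only exact number so far. Compound 1 `COc1ccc(C=C2C(=O)N(c3ccc(Cl)cc3)N(c3ccc(Cl)cc3)C2=O)cc1` reaches only a limit in this assay, > 128000 nM. Within the data shown here, the one measured step, an at least 8.8-fold lower number from compound 1 to compound 2 (0.94 log units; beyond the scatter), shows that a change at this place can move the number, but it involves a different exchange and gives no direction here. Compound 3 `O=C1C(=C/C=C/c2ccccc2)C(=O)N(c2ccc(Cl)cc2)N1c1ccc(Cl)cc1` differs from compound 2 at that same place: 2-phenylethenyl in place of 3-chlorophenyl on a double-bonded chain carbon bound to a double-bonded ring carbon. The expected step is a 1.0-fold higher number from compound 2 to compound 3 (0.02 log units; within the scatter), with nothing beyond the scatter foreseen, though with wide uncertainty. For compound 3 the estimated value is 15000 nM, within an expected range of 4000 nM to 55000 nM.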

Compound 3, half-maximal inhibitory concentration: 5100 nM
Beside the measured number, compound 3's estimate is 2.9-fold (0.47 log units) above it; the measured number falls inside the stated range.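

In this assay, 2-phenylethenyl, with its double bond outside aromatic rings, gives the lowest number of the three at this position, going further than 3-chlorophenyl: a 2.8-fold lower number from compound 2 to compound 3 (0.45 log units; beyond the scatter). Against 4-methoxyphenyl the change reads as an at least 25-fold lower number from compound 1 to compound 3 (1.39 log units; beyond the scatter). For compound 1 this rests on a limit of the assay, not a number: the limit of > 128000 nM in this assay, at which 1 of the 3 values shown sits.

From the compounds shown here alone, whether the lower number goes with the added double bond or with the loss of the chlorine stays open, for the two change together in one step. Also open, going by these compounds, is how an amine, a carboxylic acid or a longer chain at this place would read.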